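This account rests on a few compounds, and the source may have more. Where it says the series, first, only, none or still open, it means among the compounds named here.

Measured so far, in a functional assay on HeLa S3 cells (Homo sapiens) for antiproliferative activity, read by XTT assay, with a stated time of 72 h; a lower number here means a stronger inhibitor, a higher number a weaker inhibitor:
- compound 1 `COc1ncnc2c1c(-c1ccsc1)cn2[C@@H]1O[C@H](CO)[C@@H](O)[C@H]1O` gives 3350 nM
- compound 2 `COc1ncnc2c1c(-c1ccoc1)cn2[C@@H]1O[C@H](CO)[C@@H](O)[C@H]1O` gives 1790 nM
- compound 3 `CNc1ncnc2c1c(-c1ccsc1)cn2[C@@H]1O[C@H](CO)[C@@H](O)[C@H]1O` reaches only the limit of this assay, > 20000 nM

Compound 2 differs from compound 1 by furan-3-yl in place of thiophen-3-yl on an aromatic carbon, and this change gave a 1.9-fold lower number from compound 1 to compound 2 (0.27 log units; within the scatter). Compound 3 differs from compound 1 in its core by methylamino in place of methoxy on an aromatic carbon, and that change gave an at least 5.9-fold higher number from compound 1 to compound 3 (0.77 log units; beyond the scatter), with compound 3 sitting at the limit of > 20000 nM in this assay, at which 1 of the 3 values shown sits.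

Compound 4 `CNc1ncnc2c1c(-c1ccoc1)cn2[C@@H]1O[C@H](CO)[C@@H](O)[C@H]1O` has not yet been measured. Among the compounds with values here, it differs from compound 3 by furan-3-yl in place of thiophen-3-yl on an aromatic carbon, the same change as the one from compound 1 to compound 2, made at a place described in the same words. Since that change stayed within the scatter between compound 1 and compound 2, as a 1.9-fold lower number from compound 1 to compound 2 (0.27 log units; within the scatter) shows, a similarly small step is expected here: a step that the limit leaves unreadable from compound 3 to compound 4. Compound 4 is therefore expected to give about 25000 nM in this assay, somewhere between 10000 nM and 60000 nM, and quite possibly again only a limit.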

Compound 4, half-maximal inhibitory concentration: > 20000 nM
Compound 4 ended at the assay's limit; the forecaster's own chance of this, stated with the estimate: 75%; the middle value does not contradict the limit.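

Methylamino in place of methoxy gave an at least 11-fold higher number from compound 2 to compound 4 (1.04 log units; beyond the scatter) in this assay, so the loss seen on the core bearing thiophen-3-yl also appears on the core bearing furan-3-yl: the same change on two cores in this assay, an at least 5.9-fold higher number (0.77 log units; beyond the scatter) from compound 1 to compound 3 and an at least 11-fold higher number (1.04 log units; beyond the scatter) from compound 2 to compound 4; the limit leaves it open whether they differ

Compound 4 gives > 20000 nM, which is a limit of this assay and not a number. The direction of the change therefore carries from one core to the other, but its exact size on either core cannot be read, and neither can the step from furan-3-yl in place of thiophen-3-yl between the two methylamino compounds, since both end at the same limit: the limit of > 20000 nM in this assay, at which 2 of the 4 values shown sit.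

The compounds shown leave open whether another group on that aromatic carbon, such as a plain amine, a dimethylamino group or an ethoxy group, would stay close to compound 1 and compound 2 or fall to the limit as well. They also leave open whether the same loss would appear with a phenyl group in place of these two five-membered rings.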